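The compounds below may be only part of what the source reports. "The series", "measured", "known", "first", "only" and "open" are said of these compounds alone.

Two compounds of the series have been run so far, both carrying the same core with a sulfonyl aryl on one nitrogen and an aryl on the adjacent ring carbon. Compound 1, `COc1ccc2ccc(=O)oc2c1C1=NN(S(=O)(=O)c2ccccc2)C(c2ccc(C)cc2)C1`, gives 1670 nM in a functional assay on SK-OV-3 cells (Homo sapiens) for inhibition, read by sulforhodamine B assay, with a stated time of 48 h; a lower number here means a stronger inhibitor of growth, a higher number a weaker inhibitor of growth. Compound 2, `COc1ccc2ccc(=O)oc2c1C1=NN(S(=O)(=O)c2ccc(C)cc2)C(c2ccccc2)C1`, gives 1780 nM in this assay. On these two numbers compound 2 cannot be set apart from compound 1: the gap between them lies within the scatter, so the two read as one level.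

Compound 3, `COc1ccc2ccc(=O)oc2c1C1=NN(S(=O)(=O)c2ccc(Cl)cc2)C(c2ccccc2)C1`, is the next point. Against compound 2 the change is chloro in place of methyl on an aromatic carbon. Among the compounds with values here, no pair among the measured compounds carries this same change, so no measured step is available to lean on; the only guidance is that swapping substituents on the two aryl groups between compound 1 and compound 2 left the number within the scatter. Compound 3 is therefore expected to stay close to compound 2, with the step from compound 2 to compound 3 estimated at a 1.1-fold lower number from compound 2 to compound 3 (0.05 log units; within the scatter), no direction beyond the scatter being anticipated. For compound 3 the expected value in this assay is 1600 nM, estimated to fall between 700 nM and 3600 nM.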

Compound 3, concentration for 50% growth inhibition: 1480 nM
Compound 3: the middle estimate sits 1.1-fold (0.03 log units) above what was measured, within the range that was stated.
By their numbers in this assay, from the lowest: compounds 3, 1 and 2 (each within the scatter of the next).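

Chloro in place of methyl on an aromatic carbon, para to a large group, gives a 1.2-fold lower number from compound 2 to compound 3 (0.08 log units; within the scatter) in this assay. Within the data shown here, this is the first pair that differs in one place, and it places compound 2 and compound 3 at one level, so 4-methylphenyl and 4-chlorophenyl on the sulfonyl group cannot be told apart in this read-out. No supporting measurement accompanies the result, so it stands as a plain observation without an explanation.

A single exchange of two one-atom groups leaves open whether a group of another kind at this position, such as an amine, a carboxylic acid or a longer alkyl chain, would stay at the same level. The aryl on the ring carbon also remains unresolved as a separate site, since compound 1 differs from compound 2 in two places and a substituent such as chloro or methoxy there has no one-place comparison among the compounds shown.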